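A few compounds are considered here, and "the series" means these few. Any claim that something is new, unique, unknown or untested is made for them only; others in the source may bear on it.

In a functional assay on A549 cells (Homo sapiens) for inhibition, read by MTT assay, with a stated time of 72 h (on this read-out lower numbers stand for stronger inhibition and higher numbers for weaker inhibition), compound 2 `Nc1nc2cc(-c3nn(CCCCC(=O)NO)c4ncnc(N)c34)ccc2o1` gives > 100000 nM, which is a limit and not a number. Compound 1 `Nc1nc2cc(-c3nn(CCCCCCCCCC(=O)NO)c4ncnc(N)c34)ccc2o1` gives > 50000 nM, which is also a limit. Only compound 3 `Nc1nc2cc(-c3nn(CCCCCCCCC(=O)NO)c4ncnc(N)c34)ccc2o1` gives a true number, 13200 nM. Compound 2 can therefore be placed against compound 3 but not against compound 1.

Compound 4 `Nc1nc2cc(-c3nn(CC(=O)NO)c4ncnc(N)c34)ccc2o1` keeps the shared core and shortens the chain: hydroxycarbamoyl in place of 3-(hydroxycarbamoyl)propyl on a saturated chain carbon bound to an aromatic nitrogen. In words, hydroxycarbamoyl stands in place of 3-(hydroxycarbamoyl)propyl on a saturated chain carbon bound to an aromatic nitrogen.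

Going by the values given here, the three measured compounds differ only in this chain, so their steps are the only guide. The step of an at least 7.5-fold lower number from compound 2 to compound 3 (0.87 log units; beyond the scatter) shows that the shorter chain of compound 2 gives the higher number. The step of an at least 3.7-fold lower number from compound 1 to compound 3 (0.57 log units; beyond the scatter) goes against any simple rule that longer is better, since compound 1 has the longer chain. The step that the two limits leave unreadable from compound 1 to compound 2 cannot be sized. No measured compound has a chain shorter than that of compound 2, so the expectation is an extrapolation, and nothing shown suggests a recovery in this assay.

The expected change is a number no higher from compound 2 to compound 4 (the limit leaves the size open), with no clear move beyond the scatter. For compound 4 the estimate is 100000 nM, with an expected range of 30000 nM to 300000 nM.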

Compound 4, half-maximal inhibitory concentration: 27700 nM
For compound 4 the middle estimate is 3.6-fold (0.56 log units) above the measured one; measured number below the stated range.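

Shortening the chain, on a saturated chain carbon bound to an aromatic nitrogen, brings the read-out off its limit: in this assay there is an at least 3.6-fold lower number from compound 2 to compound 4 (0.55 log units; beyond the scatter). Going by these compounds alone, until now the only readable moves away from compound 2 led to longer chains, so this is the first sign that a shorter chain can also give a lower number, and compound 2 now sits higher than both compound 3 and compound 4, with chain length acting in no single direction. The true size of this step stays open because compound 2 has only a limit and not a number: the limit of > 100000 nM in this assay, at which 1 of the 4 values shown sits.

The compounds shown do not say why the number changes with the chain, nor how a chain of a length between those of compound 4 and compound 2 would read. On these data alone, it is also open whether a carboxylic acid or a primary amide at the chain end, in place of hydroxycarbamoyl, would keep a measurable number in this assay.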